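Cytotoxicity of a Shared Core with Varied Amino Substituents

A few compounds are considered here, and "the series" means these few. Any claim that something is new, unique, unknown or untested is made for them only; others in the source may bear on it.

Measured compounds:
Compound 1 `CCOC(=O)CCCNc1ncc(C(Oc2ccc3cc(Br)ccc3c2)c2ccc(Cl)cc2)s1` — "not toxic" (no number reported)
Compound 2 `O=C(Nc1ncc(C(Oc2ccc3cc(Br)ccc3c2)c2ccc(Cl)cc2)s1)C1CCOCC1` — "not toxic" (no number reported)
Compound 3 `COc1ccc(C(=O)Nc2ncc(C(Oc3ccc4cc(Br)ccc4c3)c3ccc(Cl)cc3)s2)cc1` — > 50000 nM

In an ADME assay on HepG2 2.2.15 cells (Homo sapiens) for cytotoxicity (on this read-out higher numbers stand for lower toxicity in this test and lower numbers for higher toxicity in this test), compound 1 is recorded as "not toxic" (no number reported) without a number. Compound 2 is recorded in this assay as "not toxic" (no number reported), again without a number. For compound 3 the result is a limit of the assay and not a number: compound 3 gives > 50000 nM. Thus compound 3 stands at the limit of > 50000 nM in this assay, at which 1 of the 3 values shown sits, and no compound in the set shows a numerical half-maximal cytotoxic concentration, so no step between measured compounds can be read.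

Compound 4 `CCc1ccc(S(=O)(=O)Nc2ncc(C(Oc3ccc4cc(Br)ccc4c3)c3ccc(Cl)cc3)s2)cc1` is the unmeasured compound. It differs from compound 3 by (4-ethylphenyl)sulfonyl in place of (4-methoxyphenyl)carbonyl on a nitrogen on an aromatic ring. Among the compounds with values here, since compound 3 gives only the limit > 50000 nM and no measured compound shows a numerical half-maximal cytotoxic concentration, compound 4 is expected to stay in that same region, and the step that the limit leaves unreadable from compound 3 to compound 4 is expected to be none beyond the scatter. Compound 4 is estimated at 60000 nM, within a range from 25000 nM to 150000 nM, most likely reported again only as a limit.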

Compound 4, half-maximal cytotoxic concentration: > 50000 nM
Compound 4 was reported as a limit (the forecaster's own chance of this, stated with the estimate: 70%); the middle value lies beyond the limit too.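

In this assay compound 4 gives > 50000 nM, a limit and not a number, so no step from compound 3 to compound 4 can be read: the limit of > 50000 nM in this assay, at which 2 of the 4 values shown sit.

The compounds shown leave open whether (4-ethylphenyl)sulfonyl and (4-methoxyphenyl)carbonyl differ at all on this read-out.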